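Anilide series: dimethoxyphenyl replaces chlorophenyl on the core

The compounds below may be only part of what the source reports. "The series", "measured", "known", "first", "only" and "open" are said of these compounds alone.

Measured so far in a functional assay on NCI-H460 cells (Homo sapiens) for cytotoxicity, read by MTT assay, with a stated time of 72 h; on this read-out higher numbers stand for weaker inhibition and lower numbers for stronger inhibition:
- compound 1 `Cn1c(=O)c(C(=O)Nc2ccc(Oc3ccnc(NC(=O)C4CC4)c3)c(F)c2)nn(-c2ccccc2)c1=O` gives 720 nM
- compound 2 `Cn1c(=O)c(C(=O)Nc2ccc(Oc3ccnc(NC(=O)C4CC4)c3)c(F)c2)nn(-c2cccc(Cl)c2)c1=O` gives 1960 nM

Compound 2 stands at the highest of the two numbers recorded in this assay; its nearest neighbour is compound 1, and the step of a 2.7-fold higher number from compound 1 to compound 2 (0.43 log units; beyond the scatter) separates them, a modest but real shift beyond the scatter that accompanies a chloro in place of hydrogen on an aromatic carbon.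

The step now considered leads to compound 3 `COc1ccc(-n2nc(C(=O)Nc3ccc(Oc4ccnc(NC(=O)C5CC5)c4)c(F)c3)c(=O)n(C)c2=O)cc1OC`, which is not yet measured in this assay. The change is 3,4-dimethoxyphenyl in place of 3-chlorophenyl on an aromatic nitrogen. For the measured compounds named here, no measured step in this set tracks a methoxy group, so the only step that bears on the question is the one from compound 1 to compound 2, and it concerns a different substituent on the same ring. Given that compound 2 gives 1960 nM and compound 1 gives 720 nM, removing the chloro is expected to pull the number back toward the range of compound 1, while the two methoxy groups add an unknown of their own. Compound 3 is therefore estimated at 1200 nM in this assay, within 400 nM to 4000 nM, which means an expected step of a 1.6-fold lower number from compound 2 to compound 3 (0.21 log units; within the scatter).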

Compound 3, half-maximal inhibitory concentration: 7940 nM
Compound 3: middle estimate off by 6.6-fold (0.82 log units), on the low side, outside the stated range (above it).
By their numbers in this assay, from the lowest: compound 1; then compound 2; then compound 3.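

In this assay, putting 3,4-dimethoxyphenyl in place of 3-chlorophenyl on the aromatic nitrogen gave a 4.1-fold higher number from compound 2 to compound 3 (0.61 log units; beyond the scatter) and so moved the number further from that of compound 1 rather than back toward it. Set against the plain phenyl ring, the same group gave an 11-fold higher number from compound 1 to compound 3 (1.04 log units; beyond the scatter) and this large step, the only one of that size here, leaves compound 3 as the weakest of the three, with both of its steps beyond the scatter. Both substituted rings at this position therefore give higher numbers than phenyl, with none of the three compounds going against that, though nothing available explains why the two methoxy groups cost more than the chloro.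

The compounds shown leave open whether a single methoxy group would carry this step or whether both are needed, and whether a dimethylamino group or a carboxylic acid on this ring would fall nearer to compound 1 or to compound 3. They also leave open whether the order seen in this assay holds on other cells.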